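This account rests on a few compounds, and the source may have more. Where it says the series, first, only, none or still open, it means among the compounds named here.

Working notes on the series, tested in a functional assay on DU-145 cells (Homo sapiens) for cytotoxicity; a higher number here means a weaker inhibitor of growth, a lower number a stronger inhibitor of growth. Of the compounds shown here, two have numbers so far. Compound 1 `COc1ccc(C2=C(c3ccc(SC)cc3)CC3CCCN3C2=O)cc1OC(=O)CNC(=O)OC(C)(C)C` gives 10000 nM, and compound 2 `CSc1ccc(C2=C(c3ccc(C)c(C)c3)C(=O)N3CCCC3C2)cc1` gives 500 nM. Compound 2 therefore holds the lower of the two numbers, and the gap to compound 1 lies beyond the scatter. For the measured compounds named here, the two compounds differ in more than one place, so their values give no measured step for any single group.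

Next is compound 3 `CSc1ccc(C2=C(c3ccc(O)cc3)C(=O)N3CCCC3C2)cc1`, which keeps the 4-(methylsulfanyl)phenyl group of compound 2 and changes the group on the double-bonded ring carbon next to it: 4-hydroxyphenyl in place of 3,4-dimethylphenyl on a double-bonded ring carbon. Going by the values given here, no measured pair covers this replacement, so the expectation is only a loose one. Compound 2, at 500 nM, is the better of just two values, and a change from that position is more likely to raise the number than to lower it. The estimated change is a 3.0-fold higher number from compound 2 to compound 3 (0.48 log units; beyond the scatter), a moderate rise that would mean weaker growth inhibition. For compound 3 the expected value is 1500 nM, with an estimated range from 300 nM to 8000 nM.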

Compound 3, concentration for 50% growth inhibition: > 100000 nM
Compound 3 gave a limit, no number (the forecaster's own chance of this, stated with the estimate: 10%); middle value at least 66-fold (1.82 log units) from the limit.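

In this assay, for the compounds shown here, the exchange of 3,4-dimethylphenyl for 4-hydroxyphenyl on the double-bonded ring carbon gives the first measured step, an at least 200-fold higher number from compound 2 to compound 3 (2.30 log units; beyond the scatter). With the 4-(methylsulfanyl)phenyl group and the rest of the core unchanged, this single replacement shows that these two groups are not interchangeable at this position, and that growth inhibition depends strongly on the group placed there. Compound 3 reads > 100000 nM, which is a limit of the assay and not a number, so the full size of the step stays unknown: the limit of > 100000 nM in this assay, at which 1 of the 3 values shown sits.

The compounds shown do not separate the gain of the 4-hydroxy group from the loss of the two methyl groups, and a 4-methylphenyl or 4-methoxyphenyl group at this position would be needed to tell these apart. Going by these compounds, whether the step extends to other groups at this position, such as a 4-aminophenyl or a 4-carboxyphenyl group, also remains open.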